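A few compounds are considered here, and "the series" means these few. Any claim that something is new, unique, unknown or untested is made for them only; others in the source may bear on it.

Measured in a physicochemical assay for solubility; on this read-out higher numbers stand for higher solubility and lower numbers for lower solubility: compound 1 `COc1cc(NC(C)CCCN2C(=O)CN(C(=O)CN)C2(C)C)c2ncccc2c1` gives 150000 ug/mL; compound 2 `COc1cc(NC(C)CCCN2C(=O)CN(C(=O)[C@H](N)C(C)C)C2(C)C)c2ncccc2c1` gives 46500 ug/mL; compound 3 `COc1cc(NC(C)CCCN2C(=O)[C@@H](C)NC2(C)C)c2ncccc2c1` gives 29800 ug/mL.

Compound 2 stands second highest of the three numbers. Its gap to compound 3 lies within the scatter, while compound 1 sits higher by a step beyond the scatter.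

Compound 4 `CC[C@H](C)[C@@H](N)C(=O)N1CC(=O)N(CCCC(C)Nc2cc(OC)cc3cccnc23)C1(C)C` differs from compound 2 in one place: methyl in place of hydrogen on a saturated chain carbon, three bonds along the chain from an amine nitrogen and a carbonyl carbon.

Within the data shown here, the one measured step that bears on this is a 3.2-fold lower number from compound 1 to compound 2 (0.51 log units; beyond the scatter), a modest drop for isopropyl in place of hydrogen. A single added methyl is a smaller change than that one, so only a small step down, if any, is expected in this assay.

Compound 4 is therefore estimated at 30000 ug/mL, range 14000 ug/mL to 65000 ug/mL, an expected step of a 1.6-fold lower number from compound 2 to compound 4 (0.19 log units; within the scatter) likely within the scatter.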

Compound 4, solubility: 29700 ug/mL
The estimate for compound 4 lay 1.0-fold (0.00 log units) above the measured number; the measured number falls inside the stated range.
By their numbers in this assay, from the lowest: compounds 4, 3 and 2 (each within the scatter of the next); then compound 1.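

In this assay, extending isopropyl to sec-butyl gives a step within the scatter (a 1.6-fold lower number from compound 2 to compound 4 (0.19 log units; within the scatter)), so this added methyl does not separate compound 4 from compound 2. Replacing hydrogen with sec-butyl on the saturated chain carbon bound to an amine nitrogen and a carbonyl carbon gives a step beyond the scatter (a 5.1-fold lower number from compound 1 to compound 4 (0.70 log units; beyond the scatter)). No available evidence gives a cause for either step.

Going by these compounds, whether a longer chain, a phenyl group or a carboxylic acid at this position would stay within the scatter of compound 2 remains open.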